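This account rests on a few compounds, and the source may have more. Where it says the series, first, only, none or still open, it means among the compounds named here.

Measured compounds:

compound 1 `COc1cc(CNCc2ccccc2)ccc1OCc1ccc(Cl)nc1` — 90000 nM
compound 2 `COc1cc(OCc2cnc(Cl)c(Cl)c2)ccc1CNCc1ccncc1` — 400 nM
compound 3 `COc1cc(CNCc2ccncc2)ccc1OCc1cnc(Cl)c(Cl)c1` — 220 nM

In a functional assay on HeLa cells (Homo sapiens) for inhibition, with a stated time of 72 h (on this read-out higher numbers stand for an effect only at larger amounts of compound and lower numbers for an effect already at smaller amounts), compound 1 gives 90000 nM, the highest of the three numbers. The nearest is compound 2 with 400 nM, and the furthest is compound 3 with 220 nM; both gaps lie well beyond the scatter, so compound 1 is the weakest of the measured set in this assay.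

Compound 4 `COc1cc(CNCC2CCCO2)ccc1OCc1ccc(Cl)nc1` has not been measured. It differs from compound 1 in one place: oxolan-2-yl in place of phenyl on a saturated chain carbon bound to an amine nitrogen. Within the data shown here, no pair of measured compounds shares this change, so the data give no direct guide to its size or direction. Compounds 2 and 3 carry other changes at the same time and cannot be read as a model for this one.

With nothing to anchor it, the step from compound 1 to compound 4 is expected to be small, a 1.3-fold lower number from compound 1 to compound 4 (0.11 log units; within the scatter), and most likely within the scatter. Compound 4 is therefore estimated at 70000 nM, with a range from 15000 nM to 250000 nM.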

Compound 4, half-maximal effective concentration: 66000 nM
Estimate against measurement, compound 4: 1.1-fold (0.03 log units) above; measured number inside the range.
By their numbers in this assay, from the lowest: compounds 3 and 2 (each within the scatter of the next); then compounds 4 and 1 (each within the scatter of the next).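

In this assay, oxolan-2-yl in place of phenyl on a saturated chain carbon bound to an amine nitrogen gives a 1.4-fold lower number from compound 1 to compound 4 (0.13 log units; within the scatter), so the two compounds cannot be told apart on this read-out. Among these compounds, this is the first reading at this position, and it shows that a six-membered aromatic ring of carbon only and a five-membered non-aromatic ring with one oxygen, which brings one hydrogen-bond acceptor by count, give numbers within the scatter of each other on the core of compound 1. Nothing available speaks to what lies behind this result. As far as these compounds go, whether a morpholine ring or a carboxylic acid at this place would also stay within the scatter of phenyl remains open. So does whether the same exchange would read alike on the core of compound 3.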